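Swapping Selenium for Sulfur on a Shared Core

The source may report more compounds than this note shows. Statements on the series, on what has been measured and on what is new or still open speak of the compounds shown alone.

Of the compounds shown here, three built on one shared core have been tested in a functional assay on PC-3 cells (Homo sapiens) for cytotoxicity, read by MTT assay, with a stated time of 72 h; a lower number here means a stronger inhibitor of growth, a higher number a weaker inhibitor of growth. Compound 1 `C[Se]/C(=N\C(=O)c1cccs1)NC(=O)c1cccs1` gives 1340 nM, compound 2 `C[Se]/C(=N\C(=O)c1sccc1Cl)NC(=O)c1sccc1Cl` gives 970 nM, and compound 3 `C[Se]/C(=N\C(=O)c1cnc2ccccc2c1)NC(=O)c1cnc2ccccc2c1` gives 2330 nM. The number for compound 3 lies beyond the usual scatter from that of compound 2, but within the scatter from that of compound 1, so compound 3 and compound 1 cannot be told apart. Compound 4 `CS/C(=N\C(=O)c1cnc2ccccc2c1)NC(=O)c1cnc2ccccc2c1` has not yet been measured. It differs from compound 3 in one place: a group of 2 heavy atoms (1 carbon, 1 sulfur; no ring) in place of a group of 2 heavy atoms (1 carbon, 1 selenium; no ring), on a carbon with a double bond to nitrogen. Among the measured compounds shown here, no measured pair shows this change, so its size is unknown. In this assay compound 4 is expected to give a somewhat higher number, a step of a 1.5-fold higher number from compound 3 to compound 4 (0.18 log units; within the scatter) that may stay within the scatter. The estimate for compound 4 is 3500 nM, with a range from 1500 nM to 9000 nM.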

Compound 4, concentration for 50% growth inhibition: 76300 nM
Compound 4: middle estimate off by 22-fold (1.34 log units), on the low side; the whole stated range lies below it.
By their numbers in this assay, from the lowest: compounds 2, 1 and 3 (each within the scatter of the next, the first and the last beyond it); then compound 4.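

In this assay, putting methylsulfanyl in place of the group of 1 carbon and 1 selenium, on a carbon with a double bond to nitrogen, gives a 33-fold higher number from compound 3 to compound 4 (1.52 log units; beyond the scatter). Among the compounds shown here, all the earlier compounds carried selenium at this position, so they could not show that this single-atom change can matter so much on this core. Going by these compounds, it remains open whether the sulfur counterparts of compound 1 and compound 2 would shift as far, and how an ethylselanyl group or an amine would read at this position. Nothing measured here accounts for the size of this step.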